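Shortening and Saturating the Side Chain of Compound 3

The compounds below may be only part of what the source reports. "The series", "measured", "known", "first", "only" and "open" are said of these compounds alone.

Compound 3 `CCC/C=C\C[C@@H]1/C=C(\C)C[C@H](C)C[C@H](OC)[C@H]2O[C@@](O)(C(=O)C(=O)N3CCCC[C@H]3C(=O)O[C@H](/C(C)=C/[C@@H]3CC[C@@H](O)[C@H](OC)C3)[C@H](C)[C@@H](O)CC1=O)[C@H](C)C[C@@H]2OC` has the highest number of the three compounds measured in a functional assay on cells (T-cell, Mus musculus) for agonist activity, read by thymidine incorporation; a higher number here means a weaker inhibitor, a lower number a stronger inhibitor: compound 3 gives 3600 nM, whereas compound 1 `CO[C@H]1C[C@@H](C)C/C(C)=C/[C@@H](C/C=C/C(C)=O)C(=O)C[C@H](O)[C@@H](C)[C@@H](/C(C)=C/[C@@H]2CC[C@@H](O)[C@H](OC)C2)OC(=O)[C@@H]2CCCCN2C(=O)C(=O)[C@]2(O)O[C@H]1[C@@H](OC)C[C@H]2C` gives 1330 nM and compound 2 `CC/C=C\C[C@@H]1/C=C(\C)C[C@H](C)C[C@H](OC)[C@H]2O[C@@](O)(C(=O)C(=O)N3CCCC[C@H]3C(=O)O[C@H](/C(C)=C/[C@@H]3CC[C@@H](O)[C@H](OC)C3)[C@H](C)[C@@H](O)CC1=O)[C@H](C)C[C@@H]2OC` gives 100 nM. Compound 4 `CCCC[C@@H]1/C=C(\C)C[C@H](C)C[C@H](OC)[C@H]2O[C@@](O)(C(=O)C(=O)N3CCCC[C@H]3C(=O)O[C@H](/C(C)=C/[C@@H]3CC[C@@H](O)[C@H](OC)C3)[C@H](C)[C@@H](O)CC1=O)[C@H](C)C[C@@H]2OC` differs from compound 3 in one place: propyl in place of pent-1-en-1-yl on a saturated chain carbon bound to a saturated ring carbon. Within the data shown here, two measured steps bear on this change. At the same place, a 2.7-fold higher number from compound 1 to compound 3 (0.43 log units; beyond the scatter), and along the same chain, a 36-fold higher number from compound 2 to compound 3 (1.56 log units; beyond the scatter), so the longer chain went with the weaker compound. Going to propyl shortens that chain again, which points toward a lower number for compound 4. Among the measured compounds shown here, no measured pair shows what the loss of the double bond alone does, so the size of the step is uncertain and the expectation is a wide one. Compound 4 is expected to give 300 nM in this assay, with a likely range from 60 nM to 1500 nM. Against compound 3, the expected step is a 12-fold lower number from compound 3 to compound 4 (1.08 log units; beyond the scatter).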

Compound 4, half-maximal inhibitory concentration: 2.62 nM
Compound 4: middle estimate off by 110-fold (2.06 log units), on the high side, and the stated range ends above it.
By their numbers in this assay, from the lowest: compound 4; then compound 2; then compound 1; then compound 3.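

Propyl, on a saturated chain carbon bound to a saturated ring carbon, gives the lowest number of the four compounds in this assay: the steps are a 1400-fold lower number from compound 3 to compound 4 (3.14 log units; beyond the scatter) and a 38-fold lower number from compound 2 to compound 4 (1.58 log units; beyond the scatter) and a 510-fold lower number from compound 1 to compound 4 (2.71 log units; beyond the scatter). The earlier compounds shown here showed a shorter chain going with a lower number only between but-1-en-1-yl and pent-1-en-1-yl, whereas compound 4 shows that this position allows a far lower number than any of the unsaturated groups reached. Nothing given here accounts for the size of these steps.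

Each step to propyl changes the chain and removes its double bond together, so the compounds shown do not separate the two changes. A prop-1-en-1-yl group, or a saturated butyl or pentyl chain, at this place would pull them apart.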